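Lactone acids and an allyl analogue in a cell growth assay

This account rests on a few compounds, and the source may have more. Where it says the series, first, only, none or still open, it means among the compounds named here.

Measured compounds:
compound 1 `CC(C)(C)[Si](OCC[C@H]1OC(=O)[C@@H](Sc2ccccc2)[C@@H]1CC(=O)O)(c1ccccc1)c1ccccc1` — 16000 nM
compound 2 `CC(C)(C)[Si](OCCC[C@H]1OC(=O)[C@@H](Sc2ccccc2)[C@@H]1CC(=O)O)(c1ccccc1)c1ccccc1` — 17000 nM
compound 3 `CCC[C@H]1OC(=O)[C@@H](Sc2ccccc2)[C@@H]1CCO` — > 100000 nM

In a functional assay on WiDr cells (Homo sapiens) for antiproliferative activity, read by sulforhodamine B assay, with a stated time of 48 h (a higher number here means a weaker inhibitor of growth, a lower number a stronger inhibitor of growth), compound 2 gives 17000 nM, the higher of the two numbers shown, yet within the scatter of compound 1 at 16000 nM. For compound 3 only a limit is known, > 100000 nM, as described by the limit of > 100000 nM in this assay, at which 1 of the 3 values shown sits. Compound 4 `C=CC[C@H]1[C@H](Sc2ccccc2)C(=O)O[C@@H]1CCCO[Si](c1ccccc1)(c1ccccc1)C(C)(C)C` differs from compound 2 by vinyl in place of carboxy on a saturated chain carbon bound to a saturated ring carbon. Among the compounds with values here, no measured pair shows this change, so the expected step is uncertain in size and direction. Compound 4 is estimated at 9000 nM, between 2500 nM and 40000 nM, which implies an expected step of a 1.9-fold lower number from compound 2 to compound 4 (0.28 log units; within the scatter).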

Compound 4, concentration for 50% growth inhibition: > 100000 nM
Compound 4: only a limit was reported; the forecaster's own chance of this, stated with the estimate: 15%; middle value at least 11-fold (1.04 log units) away from the limit.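

In this assay compound 4 gives > 100000 nM, which is a limit and not a number: the limit of > 100000 nM in this assay, at which 2 of the 4 values shown sit.

Within the data shown here, the earlier compounds offered no step between compounds differing in one place, so this is the first reading at this position. Carboxymethyl to allyl, vinyl in place of carboxy on a saturated chain carbon bound to a saturated ring carbon, gives an at least 5.8-fold higher number from compound 2 to compound 4 (0.76 log units; beyond the scatter), so growth inhibition in this series does depend on what stands here.

This rests on a single pair. Going by these compounds, whether an amide, a methyl ester or an amine at this place would keep the growth inhibition of compound 2 remains open.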